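The source may report more compounds than this note shows. Statements on the series, on what has been measured and on what is new or still open speak of the compounds shown alone.

Measured compounds, with their numbers in an ADME assay on HEK293 cells (Homo sapiens) for antiproliferative activity, read by MTT assay, with a stated time of 24 h; a lower number here means a stronger inhibitor, a higher number a weaker inhibitor:
compound 1 `COc1ccc(-c2cc(C(=O)/C=C/c3ccc(Cl)cc3)nc3cc(-c4ccccc4)nn23)cc1OC` gives 39100 nM
compound 2 `COc1ccc(-c2cc(/C=C/C(=O)c3ccc(OC)c(OC)c3)nc3cc(-c4ccccc4)nn23)cc1` gives 48500 nM
compound 3 `COc1ccc(C(=O)/C=C/c2cc(-c3ccc(OC)cc3)n3nc(-c4ccccc4)cc3n2)cc1` gives 36100 nM

In figures compound 2 has the largest of the three numbers, but its gaps to compound 1 and to compound 3 both lie within the usual scatter, so the three compounds cannot be told apart on these data. Compound 4 `COc1ccc(C(=O)/C=C/c2cc(-c3ccc(OC)c(OC)c3)n3nc(-c4ccccc4)cc3n2)cc1OC` differs from compound 2 by methoxy in place of hydrogen on an aromatic carbon. One measured step speaks to this change: a 1.3-fold lower number from compound 2 to compound 3 (0.13 log units; within the scatter), which runs the other way, hydrogen in place of methoxy on an aromatic carbon, and stays within the scatter. Within the data shown here, no measured step adds a methoxy at the place concerned. On this basis the change in compound 4 is expected to shift the number in this assay by no more than the scatter, with no clear direction, so the estimated step is a 1.1-fold lower number from compound 2 to compound 4 (0.03 log units; within the scatter). Compound 4 is therefore estimated at 45000 nM, with a range from 22000 nM to 90000 nM.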

Compound 4, half-maximal inhibitory concentration: 32500 nM
Compound 4: middle estimate off by 1.4-fold (0.14 log units), on the high side; the range from low to high includes it.
By their numbers in this assay, from the lowest: compounds 4, 3, 1 and 2 (each within the scatter of the next).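

In this assay, among these compounds, the change from 4-methoxyphenyl to 3,4-dimethoxyphenyl is the first measured case of a methoxy entering at this place, ortho to a methoxy group and meta to a large group, and it gives a 1.5-fold lower number from compound 2 to compound 4 (0.17 log units; within the scatter), so the added group cannot be told from no change. The other measured step, which takes away a methoxy at a different place, gives a 1.3-fold lower number from compound 2 to compound 3 (0.13 log units; within the scatter), so neither adding nor removing one of these groups moves the number beyond the scatter in these compounds. No other measurement here offers an explanation for this result.

On these data alone, it remains open whether a different group at this position, such as an amine, a carboxylic acid or a longer chain like butoxy, would shift the number beyond the scatter.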